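Selenium-linked bis-amides: one swap, an expected cytotoxicity

This account rests on a few compounds, and the source may have more. Where it says the series, first, only, none or still open, it means among the compounds named here.

Compound 1 `O=C(/N=C(/NC(=O)c1csc([N+](=O)[O-])c1)[Se]Cc1ccccc1)c1csc([N+](=O)[O-])c1` was tested in a functional assay on HepG2 cells (Homo sapiens) for cytotoxicity, read by MTT assay, with a stated time of 72 h (a lower number here means that less compound is tolerated, a higher number that more compound is tolerated), where compound 1 gives 91600 nM. Two compounds built on a different core accompany it: compound 3 `O=C(/N=C(/NC(=O)c1cnc2ccccc2c1)[Se]Cc1ccccc1)c1cnc2ccccc2c1` gives 90300 nM, and compound 2 `C[Se]/C(=N\C(=O)c1cnc2ccccc2c1)NC(=O)c1cnc2ccccc2c1` gives 87800 nM. The difference between the core of compound 1 and the core of compound 3 is not broken down here. Compound 2 arises from compound 3 by a single change, (hydrogen in place of phenyl on a saturated chain carbon bound to a selenium atom), and the step was a 1.0-fold lower number from compound 3 to compound 2 (0.01 log units; within the scatter). Compound 4 `C[Se]/C(=N\C(=O)c1csc([N+](=O)[O-])c1)NC(=O)c1csc([N+](=O)[O-])c1` is not yet measured; it arises from compound 1 by the same change, (hydrogen in place of phenyl on a saturated chain carbon bound to a selenium atom). In this assay the expected step is a 1.0-fold lower number from compound 1 to compound 4 (0.01 log units; within the scatter), because the earlier step of a 1.0-fold lower number from compound 3 to compound 2 (0.01 log units; within the scatter) lay within the scatter. Compound 4 is therefore estimated at 90000 nM, with a likely range from 45000 nM to 180000 nM.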

Compound 4, concentration lethal to 50% of the cells: 10000 nM
For compound 4 the middle estimate is 9.0-fold (0.95 log units) above the measured one, outside the stated range (below it).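

In this assay, the change from benzyl to methyl gives a 9.2-fold lower number from compound 1 to compound 4 (0.96 log units; beyond the scatter), so on the core of compound 1 this swap leaves cells tolerating much less compound. The swap therefore does not carry over with one fixed size, and its result depends on the core it is made on: the same change on two cores in this assay, a 1.0-fold lower number (0.01 log units; within the scatter) from compound 3 to compound 2 and a 9.2-fold lower number (0.96 log units; beyond the scatter) from compound 1 to compound 4, 8.9-fold (0.95 log units) apart, beyond the scatter of two such steps

Among the compounds shown here, with only two cores, this does not show which part of the core decides the outcome, or how it does so. The compounds shown leave open whether an ethyl group or a longer chain in place of methyl would split the two cores in the same way. Going by these compounds, it also remains open whether a benzyl ring bearing an amine would behave like benzyl itself.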